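Swapping a dichlorophenoxy group for a fluorophenylsulfanyl group

The source may report more compounds than this note shows. Statements on the series, on what has been measured and on what is new or still open speak of the compounds shown alone.

Compound 1 `Nc1cc(N)c2nc(-c3ccccc3)c(Oc3ccc(Cl)c(Cl)c3)nc2c1` is the point of reference here. Going by the values given here, in a functional assay on MDA-MB-231 cells (Homo sapiens) for inhibition, read by sulforhodamine B assay, with a stated time of 48 h (on this read-out lower numbers stand for higher toxicity in this test and higher numbers for lower toxicity in this test), compound 1 gives 66100 nM, the only plain number among the values shown. Compound 2 `CCOC(=O)[C@H](CCC(=O)O)NC(=O)c1ccc(Sc2nc3cc(N)cc(N)c3nc2-c2ccccc2)cc1` shares the core of compound 1 but carries a different group on it. In this assay compound 2 gives < 100000 nM, which is a limit of the assay and not a number; this is the limit of < 100000 nM in this assay, at which 1 of the 2 values shown sits. Compound 3 `Nc1cc(N)c2nc(-c3ccccc3)c(Sc3ccc(F)cc3)nc2c1` has not yet been measured. It differs from compound 1 in one place: (4-fluorophenyl)sulfanyl in place of 3,4-dichlorophenoxy on an aromatic carbon. Among the compounds with values here, no measured pair shows what such a change does in this setting, so the expectation rests on compound 1 alone. The expected step of a 1.3-fold lower number from compound 1 to compound 3 (0.12 log units; within the scatter) is therefore small, in no clear direction, and may well stay within the usual scatter. For compound 3 the estimate in this assay is 50000 nM, with a range from 15000 nM to 120000 nM.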

Compound 3, concentration lethal to 50% of the cells: 83200 nM
Compound 3: the middle estimate sits 1.7-fold (0.22 log units) below what was measured, within the range that was stated.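

In this assay, placing (4-fluorophenyl)sulfanyl instead of 3,4-dichlorophenoxy on this aromatic carbon gives a 1.3-fold higher number from compound 1 to compound 3 (0.10 log units; within the scatter). Going by these compounds alone, this is the first measured pair at this position, and it shows that exchanging one of these groups for the other, each with one six-membered aromatic ring of carbon only, leaves the read-out within the scatter, even though the linking oxygen becomes sulfur and the two chlorines give way to one fluorine. Compound 2 still gives only a limit of the assay and not a number, so it adds no measured step: the limit of < 100000 nM in this assay, at which 1 of the 3 values shown sits.

The pair changes the linking atom and the ring halogens together, so a 4-fluorophenoxy group would be needed to separate the two changes. It also leaves open how this position responds to a group of a different kind, such as a simple amine or a carboxylic acid.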